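The source may report more compounds than this note shows. Statements on the series, on what has been measured and on what is new or still open speak of the compounds shown alone.

Measured in a physicochemical assay, read by spectrophotometry, with a stated time of 25 min; on this read-out lower numbers stand for stronger inhibition and higher numbers for weaker inhibition:
- compound 1 `O=c1cc(-c2ccccc2)oc2cc(OCCCCNc3nc4ccc(Cl)cc4s3)cc(O)c12`: 13.2 ug/mL
- compound 2 `O=c1cc(-c2ccccc2)oc2cc(OCCCCNc3nc4ccc(C(F)(F)F)cc4s3)cc(O)c12`: 16.3 ug/mL

Not yet measured:
- compound 3 `O=c1cc(-c2ccccc2)oc2cc(OCCCCNNc3nc4ccccc4s3)cc(O)c12`

Compound 1 has only compound 2 to compare with, and their two values lie within the scatter of each other. Going to compound 3, (1,3-benzothiazol-2-yl)amino takes the place of 6-chloro-1,3-benzothiazol-2-yl on an amine nitrogen: (1,3-benzothiazol-2-yl)amino in place of 6-chloro-1,3-benzothiazol-2-yl on an amine nitrogen. Among the compounds with values here, one measured step bears on this, the swap of chloro for trifluoromethyl on an aromatic carbon: a 1.2-fold higher number from compound 1 to compound 2 (0.09 log units; within the scatter). Within the data shown here, no measured step covers the added amino, so the range stays wide. No step beyond the scatter is expected in this assay. The expected step is a 1.0-fold lower number from compound 1 to compound 3 (0.01 log units; within the scatter). For compound 3 the estimate is 13 ug/mL, with an expected range of 6.5 ug/mL to 26 ug/mL.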

Compound 3, half-maximal inhibitory concentration: 24.3 ug/mL
Compound 3: the middle estimate sits 1.9-fold (0.27 log units) below what was measured, and the stated range covers the measured number.
By their numbers in this assay, from the lowest: compounds 1, 2 and 3 (each within the scatter of the next).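

In this assay, (1,3-benzothiazol-2-yl)amino in place of 6-chloro-1,3-benzothiazol-2-yl gives a 1.8-fold higher number from compound 1 to compound 3 (0.27 log units; within the scatter). This change is larger than the earlier swap on the aromatic carbon: it adds an amino link and a hydrogen-bond donor and removes the chloro, yet the step stays within the scatter. No measurement here offers an explanation for this result.

The added amino and the missing chloro arrive together, so their separate contributions cannot be told apart. As far as these compounds go, how a longer chain or a carboxylic acid at this amine nitrogen would read remains open.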